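Swapping a Methylpyridine Arm for a Chlorophenyl Arm

The compounds below may be only part of what the source reports. "The series", "measured", "known", "first", "only" and "open" are said of these compounds alone.

Compound 1 `Cc1ccc(CNC(=S)Nc2ccc(C(=O)Nc3ccccc3N)cc2)cn1` is one of two compounds tested in a functional assay on HepG2 cells (Homo sapiens) for cytotoxicity, read by MTT assay, with a stated time of 72 h; on this read-out higher numbers stand for weaker inhibition and lower numbers for stronger inhibition. In this assay compound 1 gives 11000 nM, the highest of the two numbers shown, which on this read-out means the weaker of the two inhibitions. The other compound, compound 2 `Nc1ccccc1NC(=O)c1ccc(CNC(=O)c2cc3cnccc3[nH]2)cc1`, is built differently and gives 1700 nM in this assay, a markedly lower number that lies beyond the usual scatter. Among the measured compounds shown here, no single-change step between measured compounds is known here, so nothing yet shows how small changes at the edge of compound 1 move the number.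

Compound 3 `Nc1ccccc1NC(=O)c1ccc(NC(=S)NCc2cccc(Cl)c2)cc1` keeps the core of compound 1 and changes one ring at its outer end: 3-chlorophenyl in place of 6-methylpyridin-3-yl on a saturated chain carbon bound to an amide-type nitrogen. For the measured compounds named here, with no measured step of this kind to lean on, the expectation is a step from compound 1 to compound 3 of a 1.6-fold lower number from compound 1 to compound 3 (0.20 log units; within the scatter), a modest move toward a lower number that may well stay inside the scatter. Compound 3 is therefore estimated at 7000 nM, with a likely range from 2500 nM to 20000 nM.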

Compound 3, half-maximal inhibitory concentration: 2600 nM
The estimate for compound 3 lay 2.7-fold (0.43 log units) above the measured number; the measured number falls inside the stated range.
By their numbers in this assay, from the lowest: compounds 2 and 3 (each within the scatter of the next); then compound 1.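

At the place named here, a saturated chain carbon bound to an amide-type nitrogen, the outer ring clearly matters: in this assay, 3-chlorophenyl in place of 6-methylpyridin-3-yl gives a 4.2-fold lower number from compound 1 to compound 3 (0.63 log units; beyond the scatter), the first single-change step known for the shared core. Both rings count 7 heavy atoms, yet they differ in more than one way: the leaving ring carries a ring nitrogen, a methyl group and 1 hydrogen-bond acceptor, while the entering ring is carbon only, with a chlorine and 0 hydrogen-bond acceptors, so this one step cannot show which of these differences moves the number. No measurement at hand bears on this step, and the reason for it remains unknown.

The compounds shown leave open whether the chlorine or the loss of the ring nitrogen carries the step, a question that an unsubstituted phenyl ring at this place would help to separate. They also leave open how the number would respond to a longer chain between the ring and the amide-type nitrogen, or to a methoxy group in place of the chlorine.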